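Primary Amine to Glycinamide: Expectation for Compound 4

The source may report more compounds than this note shows. Statements on the series, on what has been measured and on what is new or still open speak of the compounds shown alone.

Among the measured compounds shown here, compound 1 `CCCCC(N)c1cc(C(F)(F)F)ccc1N1CCN(C(=O)CCc2ccc(Cl)cc2Cl)CC1` gives 190 nM in an assay on HEK293 cells for displacement of a labelled ligand from Melanocortin receptor 4 (Homo sapiens) (on this read-out higher numbers stand for weaker inhibition and lower numbers for stronger inhibition), the lowest of the three numbers known: compound 2 `Cc1cccc(CCC(=O)N2CCN(c3ccc(C(F)(F)F)cc3[C@@H](N)CC(C)C)CC2)c1` gives 2100 nM and compound 3 `COc1cc(OC)c(OC)cc1CCC(=O)N1CCN(c2ccc(C(F)(F)F)cc2[C@@H](N)CC(C)C)CC1` gives 6100 nM. For the measured compounds named here, the only measured step, a 2.9-fold higher number from compound 2 to compound 3 (0.46 log units; beyond the scatter), alters the aryl group on the chain and so does not bear on the change to compound 4 `CCC(C)[C@H](NC(=O)CN)c1cc(C(F)(F)F)ccc1N1CCN(C(=O)CCc2ccc(Cl)cc2Cl)CC1`, which differs from compound 1 by 1-(((aminomethyl)carbonyl)amino)-2-methylbutyl in place of 1-aminopentyl on an aromatic carbon. Going by the values given here, no measured step touches that side of the shared core, so a step beyond the scatter in either direction cannot be ruled out, while the rest of compound 1 is kept unchanged. Compound 4 is therefore estimated at 350 nM, within 60 nM to 2000 nM, which would mean an expected 1.8-fold higher number from compound 1 to compound 4 (0.27 log units; within the scatter).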

Compound 4, inhibition constant: 18 nM
Estimate against measurement, compound 4: 19-fold (1.29 log units) above, and the stated range ends above it.
By their numbers in this assay, from the lowest: compound 4; then compound 1; then compound 2; then compound 3.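

At the aromatic carbon meta to the trifluoromethyl group, 1-(((aminomethyl)carbonyl)amino)-2-methylbutyl in place of 1-aminopentyl gives an 11-fold lower number from compound 1 to compound 4 (1.02 log units; beyond the scatter) in this assay, so this side of the shared core clearly affects the number, which the earlier aryl step could not show. The larger group, with its added carbonyl and second nitrogen, is compatible with a lower number here. Nothing shown explains the step.

The change alters both the chain and the nitrogen substituent, so their separate contributions stay unresolved. On these data alone, it also remains open whether a longer chain between carbonyl and amine, or a carboxylic acid in place of the amine, would keep this lower number.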